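Trimming Trifluoromethyl Back to Fluoro on the Core

A few compounds are considered here, and "the series" means these few. Any claim that something is new, unique, unknown or untested is made for them only; others in the source may bear on it.

Compound 1: `c1cncc(-c2nc3ccccc3n2C2CC2)c1`, 49 nM in an assay on V79 cells for inhibition of cytochrome P450 11B2, mitochondrial (Homo sapiens), read by HTRF, with a stated time of 1 h; a lower number here means a stronger inhibitor, a higher number a weaker inhibitor
Compound 2: `FC(F)(F)c1ccc2c(c1)nc(-c1cccnc1)n2C1CC1`, > 10000 nM

Compound 1 carries only hydrogen at the position in question and gives a clear number in this assay. Compound 2 bears a trifluoromethyl on an aromatic carbon of the shared core, and its result in this assay is a limit of the assay, not a number: for compound 2 only > 10000 nM is known, so it sits at the weak end of what has been measured (the limit of > 10000 nM in this assay, at which 1 of the 2 values shown sits).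

Compound 3, `Fc1ccc2c(c1)nc(-c1cccnc1)n2C1CC1`, differs from compound 2 by fluoro in place of trifluoromethyl on an aromatic carbon. Among the compounds with values here, the only measured step that bears on this change is an at least 200-fold higher number from compound 1 to compound 2 (2.30 log units; beyond the scatter). The change to compound 3 removes most of that group but keeps one fluorine in its place, so a partial reversal of that large loss is expected rather than a full return to the level of compound 1. For compound 3 in this assay an estimated 500 nM is expected, within 50 nM to 5000 nM, which amounts to an expected at least 20-fold lower number from compound 2 to compound 3 (1.30 log units; beyond the scatter).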

Compound 3, half-maximal inhibitory concentration: 28 nM
Compound 3: the middle estimate sits 18-fold (1.25 log units) above what was measured, outside the stated range (below it).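

In this assay, this position on the shared core proves open to substitution: going from trifluoromethyl back to fluoro gives an at least 350-fold lower number from compound 2 to compound 3 (2.55 log units; beyond the scatter), and the single fluorine is not separated from hydrogen, with a 1.8-fold lower number from compound 1 to compound 3 (0.24 log units; within the scatter). Among these compounds, then, the loss belongs to trifluoromethyl and not to every replacement of hydrogen at this aromatic carbon, and removing the group's carbon and two of its fluorines recovers the whole of the loss rather than part of it. For compound 2, the value of > 10000 nM is a limit of the assay and not a number, so the first step gives only a bound on the size of the change: the limit of > 10000 nM in this assay, at which 1 of the 3 values shown sits.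

The compounds shown leave open where between fluoro and trifluoromethyl the loss sets in, which a chloro, methyl or methoxy group at this position could help to place, and whether an amine or a carboxylic acid would be accepted here at all. They also leave open whether fluoro on another carbon of the same six-membered aromatic ring would be equally well accepted.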